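The compounds below may be only part of what the source reports. "The series", "measured", "known", "first", "only" and "open" are said of these compounds alone.

Measured so far in a functional assay on NCI-H226 cells (Homo sapiens) for inhibition, read by MTT assay, with a stated time of 72 h; a higher number here means a weaker inhibitor of growth, a lower number a stronger inhibitor of growth:
compound 1, `COC(=O)c1nc(C)n(-c2ccccc2)n1`, a limit of the assay, > 100000 nM
compound 2, `COC(=O)c1nc(C)n(-c2ccc(C(F)(F)F)cc2)n1`, 16600 nM
compound 3, `COC(=O)c1nc(C)n(-c2ccc(OC)cc2)n1`, a limit of the assay, > 100000 nM

Among the measured compounds shown here, compound 2 thus stands as the only measured number in this assay; the other two values sit at the limit of > 100000 nM in this assay, at which 2 of the 3 values shown sit. The step from compound 1 to compound 2 is an at least 6.0-fold lower number from compound 1 to compound 2 (0.77 log units; beyond the scatter), the step from compound 2 to compound 3 is an at least 6.0-fold higher number from compound 2 to compound 3 (0.77 log units; beyond the scatter), and the step from compound 1 to compound 3 is a step that the two limits leave unreadable from compound 1 to compound 3. Both readable steps concern only the exchange of trifluoromethyl, methoxy and hydrogen.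

Compound 4, `COC(=O)c1nc(-c2ccc[nH]2)n(-c2ccc(C(F)(F)F)cc2)n1`, keeps the trifluoromethyl of compound 2 and differs from it only in the shared core: 1H-pyrrol-2-yl in place of methyl on an aromatic carbon. For the measured compounds named here, none of the measured steps touches that carbon, so no measured step bears on this change, and the series gives no direction for it. For compound 4 the expected step is a 1.1-fold lower number from compound 2 to compound 4 (0.04 log units; within the scatter), none beyond the scatter, with a wide margin either way. Compound 4 is therefore estimated at 15000 nM, within a range from 3000 nM to 80000 nM.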

Compound 4, concentration for 50% growth inhibition: 5650 nM
The estimate for compound 4 lay 2.7-fold (0.42 log units) above the measured number; the measured number falls inside the stated range.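

In this assay, among the compounds shown here, the aromatic carbon between two ring nitrogen atoms, which no earlier step touched, proves open to change: a 2.9-fold lower number from compound 2 to compound 4 (0.47 log units; beyond the scatter). With the trifluoromethyl kept, this carbon accepts a five-membered aromatic ring carrying a hydrogen-bond donor in place of methyl, and the number moves down rather than up, so this position as well as the aromatic substituent on the trifluoromethyl-bearing ring can shift the read-out beyond the scatter. Nothing at hand accounts for the size or direction of this step.

On these data alone, whether the ring hydrogen on the pyrrole nitrogen matters stays open, and a furan-2-yl or phenyl group at this carbon would bear on that. Also open, as far as these compounds go, is whether 1H-pyrrol-2-yl acts the same way with hydrogen or methoxy in place of trifluoromethyl, or with a carboxylic acid in place of the methoxycarbonyl group.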